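Adding a Second Fluorine to a Tolerated Scaffold

A few compounds are considered here, and "the series" means these few. Any claim that something is new, unique, unknown or untested is made for them only; others in the source may bear on it.

Compound 1 `CC(=O)c1cc(-c2ccc(F)cc2)cc2cc(-c3ccccc3)[nH]c12` and compound 2 `CC(=O)c1cc(-c2ccccc2)cc2cc(-c3ccc(F)cc3)[nH]c12` share one core and differ only in which phenyl group carries the fluorine. In a functional assay on MCF7 cells (Homo sapiens) for cytotoxicity, read by MTT assay, with a stated time of 2 days (a higher number here means that more compound is tolerated, a lower number that less compound is tolerated), compound 1 gives only a limit, > 100000 nM, and not a number. In this assay compound 2 likewise gives only a limit, > 100000 nM. Compound 2 therefore stands at the limit of > 100000 nM in this assay, at which 2 of the 2 values shown sit, and the numbers shown give no way to order it against compound 1.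

Compound 3 `CC(=O)c1cc(-c2ccc(F)cc2)cc2cc(-c3ccc(F)cc3)[nH]c12` is the compound in which both phenyl groups carry the fluorine. The difference from compound 2 is fluoro in place of hydrogen on an aromatic carbon. Within the data shown here, no pair of measured compounds traces this step, so its size has to be judged from the two limits alone. Both measured compounds sit at the same limit, and nothing in the data points to a change beyond the scatter; the step from compound 2 to compound 3 is expected to be a step that the limit leaves unreadable from compound 2 to compound 3, essentially none. For compound 3 the estimate in this assay is 150000 nM, with a range from 50000 nM to 500000 nM, and it is expected that the assay again reports only a limit rather than a number.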

Compound 3, concentration lethal to 50% of the cells: 87400 nM
For compound 3 the middle estimate is 1.7-fold (0.23 log units) above the measured one; the range from low to high includes it.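

With fluoro on both phenyl groups, compound 3 is the only one of the three to return a number rather than a limit in this assay, at 87400 nM. Going from phenyl to 4-fluorophenyl on the one phenyl group gives an at least 1.1-fold lower number from compound 2 to compound 3 (0.05 log units; that floor lies within the scatter), and the same change on the other phenyl group gives an at least 1.1-fold lower number from compound 1 to compound 3 (0.05 log units; that floor lies within the scatter). Both steps are floors and not sizes, so neither shows a change beyond the scatter, and the two compounds they start from share a single limit: the limit of > 100000 nM in this assay, at which 2 of the 3 values shown sit.

The compounds shown leave open how large either step really is, and whether one of the two fluoro groups counts for more than the other, as the starting compounds cannot be ordered. They also leave open what chloro, methoxy, an amine or a carboxylic acid would do in place of fluoro on either phenyl group, and whether the number seen for compound 3 belongs to fluoro in particular or would appear with other groups at these places on the shared core.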